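The compounds below may be only part of what the source reports. "The series", "measured", "known", "first", "only" and "open" are said of these compounds alone.

Working notes on the cyanoguanidine series. Compound 1 `C/N=C(\NC#N)NCCSCn1nc(-c2ccccc2)ccc1=O` is the parent. In a functional assay on the whole organism (stomach) for inhibition, with Rattus norvegicus as the target, with a stated time of 4 h (a higher number here means that more compound is needed for the effect, a lower number that less compound is needed), compound 1 gives only a limit, < 30.5 mg/kg. Compound 2 `C/N=C(\NC#N)NCCSCn1nc(-c2ccc(C)cc2)ccc1=O` differs by a methyl in place of hydrogen on an aromatic carbon. In this assay compound 2 likewise gives only a limit, < 53.8 mg/kg. The step that the two limits leave unreadable from compound 1 to compound 2 is therefore not readable. Compound 3 `C/N=C(\NC#N)NCCSCCn1nc(-c2ccccc2)ccc1=O` is the third member. In this assay compound 3 again gives only a limit, < 80 mg/kg, so it stands with the others at an unresolved position. The evidence on the measured steps amounts to the limit of < 30.5 mg/kg in this assay, at which 1 of the 3 values shown sits, the limit of < 53.8 mg/kg in this assay, at which 1 of the 3 values shown sits, and (the limit of < 80 mg/kg in this assay, at which 1 of the 3 values shown sits), none of which yields a step size.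

Compound 4 `CC/N=C(\NC#N)NCCSCCn1nc(-c2ccccc2)ccc1=O` carries the change (methyl in place of hydrogen on a saturated chain carbon bound to a double-bonded nitrogen), cut one bond further out a methyl to ethyl. Among the compounds with values here, no measured step bears on this change; with only limits in hand, the step that the limit leaves unreadable from compound 3 to compound 4 is expected to stay within the scatter. Compound 4 is estimated at 30 mg/kg, within 5 mg/kg to 120 mg/kg, most likely reported again as a limit.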

Compound 4, dose for half-maximal effect: < 100 mg/kg
Compound 4 gave a limit, no number; the forecaster's own chance of this, stated with the estimate: 85%; the middle value lies beyond the limit too.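

In this assay compound 4 gives only a limit, < 100 mg/kg, so the step from compound 3 to compound 4 cannot be read. The compounds shown leave open the actual dose each one needs, and so whether methyl to ethyl changes it at all.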